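A few compounds are considered here, and "the series" means these few. Any claim that something is new, unique, unknown or untested is made for them only; others in the source may bear on it.

Compound 2 `COc1ccc(-c2cn(-c3cccc(C(=O)/C=C/c4cc(OC)c(OC)c(OC)c4)c3)c(=O)[nH]2)cc1` gives, in a functional assay on MDA-MB-435 cells (Homo sapiens) for inhibition (on this read-out lower numbers stand for stronger inhibition of growth and higher numbers for weaker inhibition of growth), a value of 1860 nM. Within the data shown here, that is the highest of the two numbers measured so far, and its nearest neighbour is compound 1 `COc1cc(/C=C/C(=O)c2cccc(-n3cc(-c4ccccc4)[nH]c3=O)c2)cc(OC)c1OC`, which in this assay gives 1200 nM; the gap between them lies within the scatter.

Compound 3 `COc1cc(/C=C/C(=O)c2cccc(-n3cc(-c4cc(OC)c(OC)c(OC)c4)[nH]c3=O)c2)cc(OC)c1OC` has not yet been measured. It differs from compound 2 by 3,4,5-trimethoxyphenyl in place of 4-methoxyphenyl on an aromatic carbon. Among the measured compounds shown here, only one measured step bears on this change: a 1.6-fold higher number from compound 1 to compound 2 (0.19 log units; within the scatter), which put a methoxy in place of hydrogen on an aromatic carbon and stayed within the scatter. Compound 3 adds two further methoxy groups of the same kind, so a step of similar size is expected, at most a slightly higher number and nothing clearly beyond the scatter.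

For compound 3 the expected value in this assay is 2200 nM, with a range from 900 nM to 5000 nM. This estimate means an expected step of a 1.2-fold higher number from compound 2 to compound 3 (0.07 log units; within the scatter).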

Compound 3, concentration for 50% growth inhibition: 2110 nM
Beside the measured number, compound 3's estimate is 1.0-fold (0.02 log units) above it; the measured number falls inside the stated range.
By their numbers in this assay, from the lowest: compounds 1, 2 and 3 (each within the scatter of the next).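

In this assay, 3,4,5-trimethoxyphenyl in place of 4-methoxyphenyl gives a 1.1-fold higher number from compound 2 to compound 3 (0.05 log units; within the scatter), and 3,4,5-trimethoxyphenyl in place of phenyl gives a 1.8-fold higher number from compound 1 to compound 3 (0.25 log units; within the scatter). Both steps lie within the scatter, so this position on the five-membered aromatic ring now shows no clear difference across phenyl, 4-methoxyphenyl and 3,4,5-trimethoxyphenyl, even with several methoxy groups present rather than only one. Nothing available here explains why these groups read alike.

All three compounds carry either bare phenyl or methoxy-bearing phenyl at this position, so the result says nothing about other kinds of group. An amine or a carboxylic acid on that phenyl ring, or a plain alkyl chain in place of the ring, might or might not move the number beyond the scatter.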